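The source may hold more compounds than are shown below. What is called first, only, known or untested is meant among the compounds shown, and "the series" means these compounds.

Measured compounds:
Compound 1 `Cn1ccc2ccc(-c3cc(Nc4ccccc4S(N)(=O)=O)cc4nccnc34)cc21` gives 37600 nM in an assay on lysate for inhibition of 6-phosphofructo-2-kinase/fructose-2,6-bisphosphatase 3 (Homo sapiens), with stated times of 0.5 min and 45 min; on this read-out lower numbers stand for stronger inhibition and higher numbers for weaker inhibition.
Compound 2 `Cn1ccc2ccc(-c3cc(Nc4ccccc4S(=O)(=O)NCC4CCOCC4)cc4nccnc34)cc21` gives > 100000 nM in this assay, a limit of the assay rather than a number.
Compound 3 `CN(C)C(=O)c1ccncc1Nc1cc(-c2ccc3ccn(C)c3c2)c2nccnc2c1` gives > 100000 nM in this assay, likewise a limit of the assay rather than a number.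

Compound 3 therefore stands at the limit of > 100000 nM in this assay, at which 2 of the 3 values shown sit, so only a floor for its potency is known. Compound 4 `Cn1cc(NC(=O)c2ccncc2Nc2cc(-c3ccc4ccn(C)c4c3)c3nccnc3c2)cn1` differs from compound 3 in one place: (1-methyl-1H-pyrazol-4-yl)amino in place of dimethylamino on a carbonyl carbon. Going by the values given here, the single measured step, an at least 2.6-fold higher number from compound 1 to compound 2 (0.42 log units; beyond the scatter), concerns a sulfonamide nitrogen in a different pair of compounds and does not touch the carbonyl position changed here, so no measured step bears directly on the move from compound 3 to compound 4. With compound 3 already at the limit, the change cannot be read against any resolved number. The step expected from compound 3 to compound 4 is a number no higher from compound 3 to compound 4 (the limit leaves the size open). Compound 4 is estimated at 100000 nM in this assay, with a range from 30000 nM to 300000 nM, and is expected most likely to be reported again as a limit.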

Compound 4, half-maximal inhibitory concentration: 26500 nM
The estimate for compound 4 lay 3.8-fold (0.58 log units) above the measured number; measured number below the stated range.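

In this assay, going by these compounds alone, the carbonyl carbon is the first place where a change brings a resolved value into view: (1-methyl-1H-pyrazol-4-yl)amino in place of dimethylamino gives an at least 3.7-fold lower number from compound 3 to compound 4 (0.57 log units; beyond the scatter). Within the data shown here, this direction differs from the only earlier step, made on a sulfonamide nitrogen, an at least 2.6-fold higher number from compound 1 to compound 2 (0.42 log units; beyond the scatter), so the group on this carbonyl carbon can lower the number rather than only leave it at the limit. The new step gives only a minimum size, with compound 3 at a limit of the assay: the limit of > 100000 nM in this assay, at which 2 of the 4 values shown sit.

Going by these compounds, whether the change follows the amide hydrogen or the pyrazole ring stays open. Methylamino or phenylamino on the same carbonyl carbon would separate the two, and a longer chain ending in an amine would test how much further this place can go.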